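Solubility of a pyridyl analogue of compound 3

This account rests on a few compounds, and the source may have more. Where it says the series, first, only, none or still open, it means among the compounds named here.

Measured so far in a physicochemical assay for solubility, using the shake flask method, in simulated intestinal fluid, measured as kinetic solubility, with a stated time of 2 h, at 25 degrees C, at pH 6.5; a higher number here means a more soluble compound, a lower number a less soluble compound:
- compound 1, `Cc1nc(C(=O)O)c(N)c2c1C(=O)N(Cc1ccccc1)C2=O`: 177000 nM
- compound 2, `Cc1nc(C(N)=O)c(N)c2c1C(=O)N(Cc1ccccc1)C2=O`: < 5000 nM
- compound 3, `Cc1noc(-c2nc(C)c3c(c2N)C(=O)N(Cc2ccc(Cl)cc2)C3=O)n1`: < 5000 nM

Compound 1 gives 177000 nM in this assay. Compound 2 gives < 5000 nM, which is a limit of the assay rather than a number. Between them lies one measured step, an at least 35-fold lower number from compound 1 to compound 2 (1.54 log units; beyond the scatter). Compound 3 gives < 5000 nM, again a limit of the assay and not a number; it sits on (the limit of < 5000 nM in this assay, at which 2 of the 3 values shown sit), so its true value is known only to lie somewhere under that mark.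

Compound 4, `Cc1noc(-c2nc(C)c3c(c2N)C(=O)N(Cc2ccc(Cl)cn2)C3=O)n1`, has not been measured. It differs from compound 3 in one place: 5-chloropyridin-2-yl in place of 4-chlorophenyl on a saturated chain carbon bound to an amide-type nitrogen in a ring. Among the measured compounds shown here, the only measured step, from an acid to an amide on a carbonyl carbon, concerns a different part of the molecule and says nothing about swapping 4-chlorophenyl for 5-chloropyridin-2-yl on a saturated chain carbon bound to an amide-type nitrogen in a ring. For the measured compounds named here, with no guiding step, the expectation is that compound 4 stays close to where compound 3 stands, most likely again at the limit, with a modest chance of a reported number just above it; the expected step is a number no lower from compound 3 to compound 4 (the limit leaves the size open). The estimate for compound 4 in this assay is therefore 5000 nM, with a range from 1500 nM to 20000 nM.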

Compound 4, solubility: < 5000 nM
Compound 4 was reported as a limit (the forecaster's own chance of this, stated with the estimate: 55%); the middle value sits exactly at the limit.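

In this assay compound 4 gives < 5000 nM, which is a limit of the assay and not a number. Among the compounds shown here, compound 3 is also reported as a limit, so no step from compound 3 to compound 4 can be read: the limit of < 5000 nM in this assay, at which 3 of the 4 values shown sit. Going by these compounds, whether 5-chloropyridin-2-yl in place of 4-chlorophenyl shifts the true value, and in which direction, stays open.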